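Chain Extension in a Cyclic Sulfonamide Series at the Dopamine Transporter

A few compounds are considered here, and "the series" means these few. Any claim that something is new, unique, unknown or untested is made for them only; others in the source may bear on it.

Measured so far:
- compound 1, `CNCCCN1Cc2ccccc2N(c2ccccc2F)S1(=O)=O`: -7%
- compound 2, `CNCCN1Cc2cc(F)ccc2N(c2ccccc2F)S1(=O)=O`: -5%

Two compounds sharing the same core have been examined in an assay on CHO cells for displacement of a labelled ligand from sodium-dependent dopamine transporter (Homo sapiens), tested at 1 uM; on this read-out lower numbers stand for less inhibition and higher numbers for more inhibition at the one concentration tested (going by the name of the read-out). Compound 1 gives -7%, and compound 2 gives -5%. Of the two numbers, compound 2 has the higher one, yet its nearest neighbour, compound 1, sits within the scatter of it, so the two readings show the same thing: no inhibition to speak of in this assay for either.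

Compound 3, `CNCCCN1Cc2cc(F)ccc2N(c2ccccc2F)S1(=O)=O`, has not been measured. It differs from compound 2 by (methylamino)methyl in place of methylamino on a saturated chain carbon, two bonds along the chain from a sulfonamide nitrogen in a ring. Since compound 1, which already carries a chain of that length, gives -7%, no step beyond the scatter is expected for this assay.

Compound 3 is therefore estimated at -5%, with a range from -20% to 12%, which means an expected step of no change at the digits printed from compound 2 to compound 3 (within the scatter).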

Compound 3, a percentage reported as inhibition, at one concentration (the size of the read-out at that concentration, not a potency): 2.5%
Estimate against measurement, compound 3: 7.5 percentage points below; measured number inside the range.
By their numbers in this assay, from the lowest: compounds 1, 2 and 3 (each within the scatter of the next).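

In this assay, (methylamino)methyl in place of methylamino on a saturated chain carbon, two bonds along the chain from a sulfonamide nitrogen in a ring, gives a number 7.5 percentage points higher from compound 2 to compound 3 (within the scatter) and so does not set the two chain lengths apart on the fluoro-bearing core. Fluoro in place of hydrogen on an aromatic carbon, now readable with the chain held constant, gives a number 9.5 percentage points higher from compound 1 to compound 3 (within the scatter) and likewise sets the two compounds apart by no more than the usual scatter. Nothing available bears on why either change leaves the reading within the scatter.

The compounds shown leave open whether a longer chain such as 3-(methylamino)propyl, or a dimethylamino group at the chain end, would give a number beyond the scatter in this assay. They also leave open whether chloro in place of fluoro on the aromatic carbon would read any differently.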